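The source may hold more compounds than are shown below. What is called first, only, known or untested is meant among the compounds shown, and "the series" means these compounds.

Compound 1 `CCCc1ccc(C#Cc2cc3cn([C@H]4C[C@H](O)[C@@H](CO)O4)c(=O)nc3o2)cc1` and compound 2 `O=c1nc2oc(C#Cc3ccccc3)cc2cn1[C@H]1C[C@H](O)[C@@H](CO)O1` share one core and differ in a single place: hydrogen in place of propyl on an aromatic carbon. In an ADME assay on HEL cells (Homo sapiens) for cytotoxicity, with a stated time of 3 days (a higher number here means that more compound is tolerated, a lower number that less compound is tolerated), compound 1 reaches only a limit, > 120000 nM. In this assay compound 2 likewise reaches only a limit, > 570000 nM. The step that the two limits leave unreadable from compound 1 to compound 2 cannot be sized because the limit of > 120000 nM in this assay, at which 1 of the 3 values shown sits, and the limit of > 570000 nM in this assay, at which 1 of the 3 values shown sits, are both limits. Compound 3 `CCCc1ccc(CCc2cc3cn([C@H]4C[C@H](O)[C@@H](CO)O4)c(=O)nc3o2)cc1` carries a different core; how its core differs from that of compound 1 is not broken down here. In this assay compound 3 gives a limit, > 130000 nM. Compound 4 `O=c1nc2oc(CCc3ccccc3)cc2cn1[C@H]1C[C@H](O)[C@@H](CO)O1` has not been measured; it differs from compound 3 by hydrogen in place of propyl on an aromatic carbon, the same change seen between compound 1 and compound 2. The step that the limit leaves unreadable from compound 3 to compound 4 is the expected one, resting on the earlier unreadable step and on the limit of compound 3. Compound 4 is expected to show about 200000 nM, probably again only a limit.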

Compound 4, half-maximal cytotoxic concentration: > 560000 nM
Compound 4: no number, only a limit; the forecaster's own chance of this, stated with the estimate: 85%; middle value at least 2.8-fold (0.44 log units) from the limit.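

Compound 2, compound 3 and compound 4 all give only limits, and the steps from compound 3 to compound 4 and from compound 2 to compound 4 cannot be read. From the compounds shown here alone, still open in this assay is the actual half-maximal cytotoxic concentration of each of the four compounds.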